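The source may hold more compounds than are shown below. What is called first, only, known or untested is meant among the compounds shown, and "the series" means these compounds.

Working notes on the series, read in a functional assay on HepG2 cells (Homo sapiens) for antiproliferative activity, read by CCK-8 assay, with a stated time of 72 h; a lower number here means a stronger inhibitor, a higher number a weaker inhibitor. Compound 2 (`Nc1ccccc1NC(=O)c1ccc(Cn2cnc3c(Nc4ccc(-c5ccccn5)cc4)nc(Cl)nc32)cc1`) gives 30100 nM, but it differs from compound 3 in more than one place and does not inform the step considered here. Compound 1 (`CCC(C)n1cnc2c(NCc3ccc(C(=O)Nc4ccccc4N)cc3)nc(Cl)nc21`) gives 2990 nM and compound 3 (`CC(C)n1cnc2c(NCc3ccc(C(=O)Nc4ccccc4N)cc3)nc(Cl)nc21`) gives 3320 nM. These two values lie within the scatter of each other, and both lie well under the number of compound 2, beyond the scatter.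

The next compound is compound 4 (`Nc1ccccc1NC(=O)c1ccc(CNc2nc(Cl)nc3c2ncn3C2CCCC2)cc1`), with cyclopentyl in place of isopropyl on an aromatic nitrogen. For the measured compounds named here, one measured step bears on this substituent: a 1.1-fold higher number from compound 1 to compound 3 (0.05 log units; within the scatter). Going by the values given here, that step changes only the open chain, and no measured step puts a cyclopentyl ring there, so the guide is thin. With that single small step as the basis, no step beyond the scatter is expected in this assay, in either direction. For compound 4 the estimated value is 3000 nM, with an expected range from 1300 nM to 7000 nM. The expected change is a 1.1-fold lower number from compound 3 to compound 4 (0.04 log units; within the scatter).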

Compound 4, half-maximal inhibitory concentration: 3430 nM
Beside the measured number, compound 4's estimate is 1.1-fold (0.06 log units) below it; the measured number falls inside the stated range.
By their numbers in this assay, from the lowest: compounds 1, 3 and 4 (each within the scatter of the next); then compound 2.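

In this assay, for the compounds shown here, a ring stands on the aromatic nitrogen for the first time in place of the open chains, and the step stays within the scatter (a 1.0-fold higher number from compound 3 to compound 4 (0.01 log units; within the scatter)). The same holds against the sec-butyl group (a 1.1-fold higher number from compound 1 to compound 4 (0.06 log units; within the scatter)), so isopropyl, sec-butyl and cyclopentyl do not separate at this position, even with 5 heavy atoms and one five-membered non-aromatic ring entering in place of 3 heavy atoms and no ring. No measurement at hand offers a reason for this level reading.

As far as these compounds go, whether the position stays as level with a hydroxyethyl chain, a piperidine ring or a benzyl group remains open. Compound 2 differs from compound 3 and compound 4 in more than one place, so its steps cannot be read for this position.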